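Replacing 4-methoxyphenyl with 2-phenylethenyl on the shared core

The source may hold more compounds than are shown below. What is called first, only, known or untested is meant among the compounds shown, and "the series" means these compounds.

Within the data shown here, in a functional assay on CAPAN-1 cells (Homo sapiens) for antiproliferative activity, with a stated time of 72 h (a lower number here means a stronger inhibitor, a higher number a weaker inhibitor), compound 1 (`CCCCC#Cc1cc([C@@H]2O[C@H](CO)[C@@H](O)[C@H]2O)n2ncnc(N)c12`) gives 1000 nM and compound 2 (`COc1ccc(-c2cc([C@@H]3O[C@H](CO)[C@@H](O)[C@H]3O)n3ncnc(N)c23)cc1`) gives 43900 nM, the higher of the two numbers so far. Compound 3 (`Nc1ncnn2c([C@@H]3O[C@H](CO)[C@@H](O)[C@H]3O)cc(/C=C/c3ccccc3)c12`) differs from compound 2 as follows: 2-phenylethenyl in place of 4-methoxyphenyl on an aromatic carbon. In words, 2-phenylethenyl stands in place of 4-methoxyphenyl on an aromatic carbon, and the entering group brings a double bond outside aromatic rings. Among the measured compounds shown here, the only measured step at this carbon is a 44-fold higher number from compound 1 to compound 2 (1.64 log units; beyond the scatter), large and beyond the scatter, with 4-methoxyphenyl in place of hex-1-yn-1-yl. For the measured compounds named here, no measured compound carries 2-phenylethenyl, so that step gives only a rough guide to size. A partial move back towards the number of compound 1 is expected. The expected change is a 5.5-fold lower number from compound 2 to compound 3 (0.74 log units; beyond the scatter), a lower number in this assay. For compound 3 the estimate is 8000 nM, with an expected range of 1500 nM to 45000 nM.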

Compound 3, half-maximal inhibitory concentration: 2600 nM
Estimate against measurement, compound 3: 3.1-fold (0.49 log units) above; the range from low to high includes it.
By their numbers in this assay, from the lowest: compound 1; then compound 3; then compound 2.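

In this assay the aromatic carbon tolerates a group bearing a six-membered aromatic ring better than compound 2 suggested, with a 17-fold lower number from compound 2 to compound 3 (1.23 log units; beyond the scatter) on exchanging 4-methoxyphenyl for 2-phenylethenyl. Both groups have 8 heavy atoms and one such ring, so neither the ring nor the heavy-atom count alone sets the number at this carbon. The comparison with hex-1-yn-1-yl gives a 2.6-fold higher number from compound 1 to compound 3 (0.41 log units; beyond the scatter) and is modest, so a ring-bearing group here comes close to the number of compound 1 without matching it.

The step from compound 2 to compound 3 changes the double bond and the methoxy oxygen together, and an unsubstituted phenyl or a saturated 2-phenylethyl group would be needed to separate the two. No measurement available here explains the difference between these groups.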